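Hydroxyethoxy in place of chloro on the core of compound 3

The source may hold more compounds than are shown below. What is called first, only, known or untested is meant among the compounds shown, and "the series" means these compounds.

Compound 3 `COc1ccccc1Oc1c(N)nc(-c2ccc(Cl)cc2)nc1Cl` gives 1030 nM in a functional assay on A-375 cells (Homo sapiens) for cytotoxicity, read by CCK-8 assay, with a stated time of 24 h (on this read-out higher numbers stand for weaker inhibition and lower numbers for stronger inhibition), the lowest of the two numbers in hand. Compound 2 `COc1ccccc1Oc1c(N)nc(-c2ccc(F)cc2)nc1Cl` gives 28200 nM, and the step of a 27-fold lower number from compound 2 to compound 3 (1.44 log units; beyond the scatter) lies beyond the scatter. Compound 1 `COc1ccccc1Oc1c(N)nc(-c2ccc(C)cc2)nc1Cl` reaches only a limit of this assay, > 80000 nM (the limit of > 80000 nM in this assay, at which 1 of the 3 values shown sits). The steps of an at least 2.8-fold lower number from compound 1 to compound 2 (0.45 log units; beyond the scatter) and an at least 77-fold lower number from compound 1 to compound 3 (1.89 log units; beyond the scatter) therefore rest on that limit and are floors rather than exact sizes. Compound 4 `COc1ccccc1Oc1c(N)nc(-c2ccc(Cl)cc2)nc1OCCO` differs from compound 3 in 2-hydroxyethoxy in place of chloro on an aromatic carbon. All three measured steps concern a different site of the shared core, so none bears directly on the present change; they show only that this assay answers strongly to a single exchange of one group. Among the compounds with values here, with no precedent at the changed site, a modest loss is expected for compound 4, carried with wide uncertainty, and the step of a 2.9-fold higher number from compound 3 to compound 4 (0.46 log units; beyond the scatter) is the estimated outcome. The number expected for compound 4 is 3000 nM, within 700 nM to 15000 nM.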

Compound 4, half-maximal inhibitory concentration: > 80000 nM
Compound 4 ended at the assay's limit; the forecaster's own chance of this, stated with the estimate: 5%; at least 26-fold (1.42 log units) between middle value and limit.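

In this assay, within the data shown here, the site next to the ring nitrogen also answers strongly to a single exchange, which the earlier compounds, all varied elsewhere on the shared core, could not show: 2-hydroxyethoxy in place of chloro gives an at least 77-fold higher number from compound 3 to compound 4 (1.89 log units; beyond the scatter). As far as these compounds go, compound 4 stands at a limit of the assay, so this step is a floor and its true size is unknown: the limit of > 80000 nM in this assay, at which 2 of the 4 values shown sit. Chloro at this site therefore goes with the measurable number of compound 3, while 2-hydroxyethoxy does not retain it, and this one exchange cannot show which feature of the entering group matters.

From the compounds shown here alone, whether a methoxy group, an amine or a shorter hydroxyalkyl chain would retain a measurable number at this site remains open. Also open, going by these compounds, is whether the same exchange would act alike on compound 2.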